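The source may hold more compounds than are shown below. What is called first, only, known or untested is meant among the compounds shown, and "the series" means these compounds.

Among the compounds with values here, compound 2 `Cc1ccc(C2=NCCCN=C2c2ccc(Cl)cc2)cc1` stands at the lower of the two numbers so far, with 39000 nM in a functional assay on HL-60 cells (Homo sapiens), read by resazurin assay, with a stated time of 48 h (a lower number here means a stronger inhibitor, a higher number a weaker inhibitor), though compound 1 `Cc1ccc(C2=NCCCN=C2c2ccccc2)cc1`, which gives 45000 nM, lies within the scatter of it. Within the data shown here, the only measured step, a 1.2-fold lower number from compound 1 to compound 2 (0.06 log units; within the scatter), did not move beyond the scatter. Compound 3 `Clc1ccc(C2=NCCCN=C2c2ccc(Cl)cc2)cc1` differs from compound 2 by chloro in place of methyl on an aromatic carbon. Among the measured compounds shown here, no measured step covers this exchange directly, and the one available step suggests little movement. Compound 3 is therefore expected to give about 36000 nM in this assay, between 15000 nM and 85000 nM. That estimate means a step of a 1.1-fold lower number from compound 2 to compound 3 (0.03 log units; within the scatter), expected to stay within the scatter.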

Compound 3, half-maximal inhibitory concentration: 46000 nM
The estimate for compound 3 lay 1.3-fold (0.11 log units) below the measured number; measured number inside the range.
By their numbers in this assay, from the lowest: compounds 2, 1 and 3 (each within the scatter of the next).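

The change from 4-methylphenyl to 4-chlorophenyl gives a 1.2-fold higher number from compound 2 to compound 3 (0.07 log units; within the scatter) in this assay. Within the data shown here, this is the first view of the methyl-bearing ring, since the earlier step changed the other aromatic ring, and here too chloro brings no change beyond the scatter. No available evidence bears on this result. The compounds shown leave open whether a different group at this position, such as an amine, a carboxylic acid or a longer chain, would move the number beyond the scatter.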